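Estimating Compound 4 from Its Measured Neighbours

The source may report more compounds than this note shows. Statements on the series, on what has been measured and on what is new or still open speak of the compounds shown alone.

In an ADME assay on microsomes from liver (Homo sapiens) for metabolic stability (a lower number here means slower removal, a higher number faster removal of the compound), compound 2 `CC(C)Oc1cc(Oc2ccc(S(C)(=O)=O)cc2)cc(-c2cncc(=O)[nH]2)c1` gives 11 mL/min/kg, while compound 1 `Cc1ccc(NC(=O)c2cc(Oc3ccc(S(C)(=O)=O)cc3)cc(OC(C)C)c2)nc1` gives 17 mL/min/kg. The two cannot be told apart: the step is a 1.5-fold lower number from compound 1 to compound 2 (0.19 log units; within the scatter). Compound 3 `CC(C)Oc1cc(Oc2ccc(S(C)(=O)=O)cc2)cc(-c2nccc(=O)[nH]2)c1` reports only a limit, < 9.8 mL/min/kg. Its steps, an at least 1.7-fold lower number from compound 1 to compound 3 (0.23 log units; that floor lies within the scatter) and an at least 1.1-fold lower number from compound 2 to compound 3 (0.05 log units; that floor lies within the scatter), also stay within the scatter.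

Compound 4 `Cc1cnc(-c2cc(Oc3ccc(S(C)(=O)=O)cc3)cc(OC(C)C)c2)[nH]c1=O` differs from compound 2 by a group of 8 heavy atoms (5 carbon, 2 nitrogen, 1 oxygen; one six-membered aromatic ring with 2 hetero atoms) in place of a group of 7 heavy atoms (4 carbon, 2 nitrogen, 1 oxygen; one six-membered aromatic ring with 2 hetero atoms), on an aromatic carbon. Going by the values given here, no measured step makes this exact change, but the nearest is the swap between two groups of equal size, an at least 1.1-fold lower number from compound 2 to compound 3 (0.05 log units; that floor lies within the scatter). On that evidence, no change beyond the scatter is expected in this assay. The expected step is a 1.1-fold higher number from compound 2 to compound 4 (0.04 log units; within the scatter). Compound 4 is estimated at 12 mL/min/kg, within an expected range of 7 mL/min/kg to 20 mL/min/kg.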

Compound 4, clearance: < 8 mL/min/kg
Compound 4 ended at the assay's limit; the forecaster's own chance of this, stated with the estimate: 30%; middle value at least 1.5-fold (0.17 log units) away from the limit.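

In this assay, compound 4 reports only a limit: the limit of < 8 mL/min/kg in this assay, at which 1 of the 4 values shown sits.

Even so, the data give an at least 2.1-fold lower number from compound 1 to compound 4 (0.32 log units; beyond the scatter), the first step in this set to pass beyond the scatter, so replacing the group of compound 1 with this methyl-bearing ring gives a readable difference. The smaller ring group gives a step that stays within the scatter: an at least 1.3-fold lower number from compound 2 to compound 4 (0.13 log units; that floor lies within the scatter).

The step for methyl in place of hydrogen, from compound 3 to compound 4, cannot be read, as both values are limits. Going by these compounds, how an ethyl or a methoxy group in place of that methyl would read remains open.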